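Swapping the halogen pattern on the benzyl ether of a glutamate analogue

This account rests on a few compounds, and the source may have more. Where it says the series, first, only, none or still open, it means among the compounds named here.

Measured so far:
compound 1 `N[C@]1(C(=O)O)[C@H]2[C@@H](C[C@H]1OCc1ccc(F)c(F)c1)[C@]2(F)C(=O)O`: 2.27 nM
compound 2 `N[C@]1(C(=O)O)[C@H]2[C@@H](C[C@H]1OCc1cc(Cl)cc(Cl)c1)[C@]2(F)C(=O)O`: 5.61 nM

In an assay on CHO cells for binding affinity to metabotropic glutamate receptor 2 (Rattus norvegicus) (a lower number here means a stronger inhibitor, a higher number a weaker inhibitor), compound 2 holds the higher of the two numbers, with compound 1 the nearer at a 2.5-fold higher number from compound 1 to compound 2 (0.39 log units; beyond the scatter). Compound 3 `N[C@]1(C(=O)O)[C@H]2[C@@H](C[C@H]1OCc1ccc(F)c(Cl)c1)[C@]2(F)C(=O)O` brings (3-chloro-4-fluorophenyl in place of 3,5-dichlorophenyl on a saturated chain carbon bound to an oxygen on a saturated carbon). Going by the values given here, only the step from compound 1 to compound 2 bears on this change, and it was modest. Since the new group shares one fluorine with compound 1 and one chlorine with compound 2, compound 3 is expected to land between the two, a small step of a 1.8-fold lower number from compound 2 to compound 3 (0.24 log units; within the scatter) in this assay. The estimate for compound 3 is 3.2 nM, within 1.5 nM to 7 nM.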

Compound 3, inhibition constant: 3.57 nM
Estimate against measurement, compound 3: 1.1-fold (0.05 log units) below; the measured number falls inside the stated range.
By their numbers in this assay, from the lowest: compounds 1, 3 and 2 (each within the scatter of the next, the first and the last beyond it).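

In this assay, chloro in place of fluoro on an aromatic carbon gives a 1.6-fold higher number from compound 1 to compound 3 (0.20 log units; within the scatter), while 3-chloro-4-fluorophenyl in place of 3,5-dichlorophenyl gives a 1.6-fold lower number from compound 2 to compound 3 (0.20 log units; within the scatter). The earlier step beyond the scatter thus divides into two changes, neither of which can be told from the scatter on its own. No supporting evidence bears on why these numbers arise. Going by these compounds, what stays open is whether a methoxy or trifluoromethyl group on the phenyl ring would keep the number close to those of these halogenated compounds.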